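This account rests on a few compounds, and the source may have more. Where it says the series, first, only, none or still open, it means among the compounds named here.

Compound 2 `COC(=O)C1=Cc2ccc(OC)cc2OC1c1cc(OC)c(OC)c(OC)c1` gives 13800 nM in a functional assay for inhibition of nuclear factor NF-kappa-B complex (Homo sapiens) (on this read-out higher numbers stand for weaker inhibition and lower numbers for stronger inhibition), the higher of two numbers, while compound 1 `COc1ccc2c(c1)OC(c1cc(OC)c(OC)c(OC)c1)C(C(=O)N(C)OC)=C2` gives 11700 nM; the step of a 1.2-fold higher number from compound 1 to compound 2 (0.07 log units; within the scatter) stays within the scatter. Compound 3 `COc1ccc2c(c1)OC(c1cc(OC)c(OC)c(OC)c1)C(/C=N/O)=C2` differs from compound 2 by a group of 3 heavy atoms (1 carbon, 1 nitrogen, 1 oxygen; no ring) in place of a group of 4 heavy atoms (2 carbon, 2 oxygen; no ring), on a double-bonded ring carbon. Among the compounds with values here, the only measured step, from compound 1 to compound 2, also exchanges the group on this carbon and is small, so no step beyond the scatter is expected in this assay. Compound 3 is therefore estimated at 13000 nM, between 5000 nM and 35000 nM, an expected step of a 1.1-fold lower number from compound 2 to compound 3 (0.03 log units; within the scatter).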

Compound 3, half-maximal inhibitory concentration: 14100 nM
Compound 3: the middle estimate sits 1.1-fold (0.04 log units) below what was measured; the measured number falls inside the stated range.
By their numbers in this assay, from the lowest: compounds 1, 2 and 3 (each within the scatter of the next).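

In this assay, a group of 3 heavy atoms carrying a hydrogen-bond donor takes the place of methoxycarbonyl on the double-bonded ring carbon (a 1.0-fold higher number from compound 2 to compound 3 (0.01 log units; within the scatter)) and of the other measured group on this carbon (a 1.2-fold higher number from compound 1 to compound 3 (0.08 log units; within the scatter)). Adding this donor, which neither earlier group has, therefore leaves the number within the scatter, so all three groups read alike at this position. Nothing available explains this result.

Going by these compounds, whether a carboxylic acid, an amine or a longer chain on this carbon would move the number beyond the scatter remains open. So does the effect of any change elsewhere on the shared core.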